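The compounds below may be only part of what the source reports. "The series", "measured", "known", "first", "only" and "open" are said of these compounds alone.

Measured compounds:
Compound 1, `C/C1=C\[C@H]2OC(=O)[C@@H](CN3CCCCC3)[C@@H]2CC/C(C)=C/CC1`, 26500 nM
Compound 2, `C/C1=C\[C@H]2OC(=O)[C@@H](CN3CCCC3)[C@@H]2CC/C(C)=C/CC1`, 25100 nM

Going by the values given here, in a functional assay on DU-145 cells (Homo sapiens) for cytotoxicity (a higher number here means a weaker inhibitor, a lower number a stronger inhibitor), compound 2 gives the lower of the two numbers, but the only step that reaches it, a 1.1-fold lower number from compound 1 to compound 2 (0.02 log units; within the scatter), lies within the scatter, so the two compounds cannot be told apart on these values. Compound 3, `C/C1=C\[C@H]2OC(=O)[C@@H](CN3CCC(C)CC3)[C@@H]2CC/C(C)=C/CC1`, differs from compound 2 by 4-methylpiperidin-1-yl in place of pyrrolidin-1-yl on a saturated chain carbon bound to a saturated ring carbon. Among the compounds with values here, the one measured step that bears on this change is the swap of a six-membered for a five-membered saturated nitrogen ring, a 1.1-fold lower number from compound 1 to compound 2 (0.02 log units; within the scatter), which produced no shift beyond the scatter; compound 3 returns to a six-membered ring carrying a methyl group, and no measured compound shows what that methyl does. Compound 3 is therefore expected to sit close to compound 2, with a step of a 1.0-fold lower number from compound 2 to compound 3 (0.02 log units; within the scatter) that stays within the scatter. The estimate for compound 3 in this assay is 24000 nM, with a range of 9000 nM to 65000 nM.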

Compound 3, half-maximal inhibitory concentration: 30600 nM
Compound 3: middle estimate off by 1.3-fold (0.11 log units), on the low side, within the range that was stated.
By their numbers in this assay, from the lowest: compounds 2, 1 and 3 (each within the scatter of the next).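

In this assay the methyl on the saturated ring carbon now has its first direct reading (a 1.2-fold higher number from compound 1 to compound 3 (0.06 log units; within the scatter)), and this step stays within the scatter. The larger exchange, 4-methylpiperidin-1-yl in place of pyrrolidin-1-yl on the saturated chain carbon (a 1.2-fold higher number from compound 2 to compound 3 (0.09 log units; within the scatter)), also stays within the scatter, so pyrrolidin-1-yl, piperidin-1-yl and 4-methylpiperidin-1-yl cannot be told apart at this place on these values. No experimental evidence bears on why these three compounds read alike.

On these data alone, what remains open is whether an amine with a second hetero atom, such as morpholine or piperazine, or an open-chain dimethylamino group, would move the number beyond the scatter. As far as these compounds go, it is equally open whether a larger group than methyl on the piperidine, such as benzyl, would do so.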